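The compounds below may be only part of what the source reports. "The series", "measured", "known", "first", "only" and "open" are said of these compounds alone.

In a functional assay on MDA-MB-231 cells (Homo sapiens) for antiproliferative activity, read by sulforhodamine B assay, with a stated time of 72 h (on this read-out higher numbers stand for weaker inhibition and lower numbers for stronger inhibition), compound 1 `O=C(/C=C/c1csc2ccccc12)c1ccccc1O` gives 5300 nM and compound 2 `O=C(/C=C/c1csc2ccccc12)c1cc(Cl)cc(Cl)c1O` gives 3300 nM and these two values lie within the usual scatter of each other. For compound 3 `O=C(/C=C/c1cc2ccccc2s1)c1cc(Cl)ccc1O` the reading of > 10000 nM is only a limit and not a number. Among the measured compounds shown here, it is the one compound of the three that sits at this limit, so its exact standing remains open.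

Compound 4 `O=C(/C=C/c1cc2ccccc2s1)c1cc(Br)ccc1O` differs from compound 3 in one place, with bromo in place of chloro on an aromatic carbon as the counted change. In words, this is bromo in place of chloro on an aromatic carbon of a six-membered aromatic ring of carbon only, para to a hydroxy group. For the measured compounds named here, no pair of measured compounds shows this swap, so no measured step gives its size. In this assay the expectation is therefore no step beyond the scatter, in either direction. The estimated move is a number no higher from compound 3 to compound 4 (the limit leaves the size open) in size and should be read as a rough guide. A reading that is again only a limit is quite possible for compound 4. The estimate for compound 4 is 10000 nM as a middle value, with an expected range from 4500 nM to 20000 nM on repeated measurement.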

Compound 4, half-maximal inhibitory concentration: > 10000 nM
Compound 4: only a limit was reported; the forecaster's own chance of this, stated with the estimate: 55%; the middle value sits exactly at the limit.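

Compound 3 and compound 4 each carry only a limit, so no step can be read between them for bromo in place of chloro on an aromatic carbon: the limit of > 10000 nM in this assay, at which 2 of the 4 values shown sit. The compounds shown leave open whether this swap changes the inhibition of these cells at all, and by how much.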